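Chain variation at the aromatic nitrogen of the shared core

The source may hold more compounds than are shown below. What is called first, only, known or untested is meant among the compounds shown, and "the series" means these compounds.

Compound 1 `C#CCCCn1c(Cc2cc(OC)c(OC)c(OC)c2)nc2c(N)nc(F)nc21` and compound 2 `C#CCCCn1c(Cc2cc(OC)c(OC)c(OC)c2)nc2c(N)ncnc21` share one core and differ only at an aromatic carbon. In a functional assay on MCF7 cells (Homo sapiens) for antiproliferative activity (on this read-out lower numbers stand for stronger inhibition and higher numbers for weaker inhibition), compound 1 gives 11000 nM, and compound 2 gives 24000 nM. The step of a 2.2-fold higher number from compound 1 to compound 2 (0.34 log units; beyond the scatter) is modest but beyond the scatter. Compound 2 therefore stands with the highest of the two numbers, its nearest neighbour being compound 1.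

Compound 3 `COc1cc(Cc2nc3c(N)ncnc3n2CC2CCCO2)cc(OC)c1OC` keeps the core of compound 2 and changes only the chain on the aromatic nitrogen: oxolan-2-yl in place of but-3-yn-1-yl on a saturated chain carbon bound to an aromatic nitrogen. Among the compounds with values here, no measured step touches this chain; the one step known, from compound 1 to compound 2, concerns the aromatic carbon and gives no guidance here. With nothing bearing on the change, no step beyond the scatter is expected in this assay, in either direction. The expected step is no change at the digits printed from compound 2 to compound 3 (within the scatter). For compound 3 the estimated value is 24000 nM, with a range from 8000 nM to 70000 nM.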

Compound 3, half-maximal inhibitory concentration: 91200 nM
Compound 3: the middle estimate sits 3.8-fold (0.58 log units) below what was measured; the whole stated range lies below it.
By their numbers in this assay, from the lowest: compound 1; then compound 2; then compound 3.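

In this assay the chain on the aromatic nitrogen proves not to be silent: the step of a 3.8-fold higher number from compound 2 to compound 3 (0.58 log units; beyond the scatter) follows from oxolan-2-yl in place of but-3-yn-1-yl and runs towards weaker inhibition. This single swap removes the triple bond and brings in a ring with an oxygen together, so the shown compounds cannot separate the two changes. No measurement at hand accounts for the step.

On these data alone, whether a saturated pentyl chain, an open-chain ether or a chain ending in an amine would fall nearer compound 2 or compound 3 remains open. Also open, as far as these compounds go, is whether fluoro on the aromatic carbon, as in compound 1, would move the oxolan-2-yl compound in the same direction as it does the but-3-yn-1-yl pair.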